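A few compounds are considered here, and "the series" means these few. Any claim that something is new, unique, unknown or untested is made for them only; others in the source may bear on it.

Measured compounds:
compound 1 `Cc1c(C(=O)Nc2ccc(Oc3ncnc4[nH]cc(-c5ccccc5)c34)c(F)c2)c(=O)c2cc(F)ccc2n1C` — in an assay on isolated protein for inhibition of tyrosine-protein kinase receptor UFO (Homo sapiens), read by FRET and Z'-LYTE, with a stated time of 1.5 h (on this read-out higher numbers stand for weaker inhibition and lower numbers for stronger inhibition), compound 1 gives > 10000 nM
compound 2 `Cc1ccc2c(c1)c(=O)c(C(=O)Nc1ccc(Oc3ncnc4[nH]cc(-c5ccccc5)c34)c(F)c1)c(C)n2C` — compound 2 gives 100 nM
compound 3 `Cc1ccc2[nH]c(C)c(C(=O)Nc3ccc(Oc4ncnc5[nH]cc(-c6ccccc6)c45)c(F)c3)c(=O)c2c1` — compound 3 gives 560 nM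

The value for compound 1 is a limit of the assay, not a number (the limit of > 10000 nM in this assay, at which 1 of the 3 values shown sits). Among the two numbers shown, compound 3 has the highest; its nearest neighbour is compound 2, with a 5.6-fold higher number from compound 2 to compound 3 (0.75 log units; beyond the scatter). Compound 4 `CCn1c(C)c(C(=O)Nc2ccc(Oc3ncnc4[nH]cc(-c5ccccc5)c34)c(F)c2)c(=O)c2cc(C)ccc21` differs from compound 3 by ethyl in place of hydrogen on an aromatic nitrogen. Among the measured compounds shown here, the only step that bears on this change is the one from compound 2 to compound 3, where hydrogen in place of methyl on that nitrogen gave a 5.6-fold higher number from compound 2 to compound 3 (0.75 log units; beyond the scatter); an ethyl restoring an alkyl there is therefore expected to give a lower number of modest size in this assay. Compound 4 is thus estimated at 150 nM (range 40 nM to 600 nM), an expected step of a 3.7-fold lower number from compound 3 to compound 4 (0.57 log units; beyond the scatter).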

Compound 4, half-maximal inhibitory concentration: 150 nM
Compound 4: the middle estimate sits on the measured number at the digits printed, and the stated range covers the measured number.
By their numbers in this assay, from the lowest: compounds 2 and 4 (each within the scatter of the next); then compound 3. At a limit, above all of these: compound 1.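

In this assay, ethyl in place of hydrogen on this aromatic nitrogen gives a 3.7-fold lower number from compound 3 to compound 4 (0.57 log units; beyond the scatter), so the lower number seen with methyl in compound 2 also appears with a second alkyl group. Going from that methyl to ethyl gives a 1.5-fold higher number from compound 2 to compound 4 (0.18 log units; within the scatter), so these two groups are not told apart at this position. Nothing in the data given explains why an alkyl group here goes with a lower number. As far as these compounds go, whether a propyl chain, a cyclopropyl ring or a 2-hydroxyethyl chain on this nitrogen would keep the number near those of compound 2 and compound 4 remains open.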